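The compounds below may be only part of what the source reports. "The series", "measured", "known", "first", "only" and "open" are said of these compounds alone.

Measured so far:
compound 1 `CCCSc1nc(N/N=C(\C)c2ccc(OC)cc2)c2nnn(Cc3ccccc3)c2n1` gives 44300 nM
compound 2 `CCCSc1nc(N/N=C(\C)c2ccc(O)cc2)c2nnn(Cc3ccccc3)c2n1` gives 16700 nM
compound 3 `COc1cc(/C=N/Nc2nc(SCc3ccccc3)nc3c2nnn3Cc2ccccc2)cc(OC)c1OC` gives 1320 nM

In a functional assay on MGC-803 cells (Homo sapiens) for antiproliferative activity, read by MTT assay, with a stated time of 72 h (a lower number here means a stronger inhibitor, a higher number a weaker inhibitor), compound 2 stands second highest of the three numbers. Its nearest neighbour is compound 1, with a 2.7-fold lower number from compound 1 to compound 2 (0.42 log units; beyond the scatter); compound 3 lies furthest, with the lowest number of the three. Compound 4 `CCCSc1nc(N/N=C/c2ccc(Br)cc2)c2nnn(Cc3ccccc3)c2n1` has not yet been measured. It differs from compound 2 in one place: a group of 9 heavy atoms (7 carbon, 1 nitrogen, 1 bromine; one six-membered aromatic ring of carbon only) in place of a group of 10 heavy atoms (8 carbon, 1 nitrogen, 1 oxygen; one six-membered aromatic ring of carbon only), on a nitrogen on an aromatic ring. Within the data shown here, the only measured step, a 2.7-fold lower number from compound 1 to compound 2 (0.42 log units; beyond the scatter), concerns the group that leaves here and says nothing about the group that enters, so no direction can be read from the series. Compound 4 is therefore expected near compound 2, with a wide range: 12000 nM (3000 nM to 50000 nM). The expected step is a 1.4-fold lower number from compound 2 to compound 4 (0.14 log units; within the scatter).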

Compound 4, half-maximal inhibitory concentration: 34900 nM
Compound 4: middle estimate off by 2.9-fold (0.46 log units), on the low side, within the range that was stated.
By their numbers in this assay, from the lowest: compound 3; then compound 2; then compounds 4 and 1 (each within the scatter of the next).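

In this assay, exchanging the whole group on the nitrogen gives a 2.1-fold higher number from compound 2 to compound 4 (0.32 log units; beyond the scatter), so the bromine-bearing group of 9 heavy atoms does not lower the number relative to the oxygen-bearing group of 10 heavy atoms. This position therefore responds to more than the methyl on the oxygen, although this single step changes several features at once and cannot separate them. Nothing available explains the rise.

Open: whether an amine or a carboxylic acid in place of the bromine would lower the number, and what a methyl on the double-bonded carbon of compound 4 alone would do.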